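Replacing Trifluoromethylphenyl with Fluorophenyl: an Expected Loss

The compounds below may be only part of what the source reports. "The series", "measured", "known", "first", "only" and "open" are said of these compounds alone.

Compound 3 `CCOC(=O)C1=Cc2ccccc2OC1(OCc1cc(-c2cccc(C(F)(F)F)c2)no1)C(F)(F)F` is the only one of the three measured compounds that gives an actual number in a functional assay on A549 cells (Homo sapiens) for inhibition, read by MTT assay, with a stated time of 24 h (a higher number here means a weaker inhibitor, a lower number a stronger inhibitor), namely 48600 nM. Compound 1 `CCOC(=O)C1=Cc2ccccc2OC1(OCc1cc(-c2ccc(C)cc2)no1)C(F)(F)F` reaches only the limit of the assay, > 150000 nM. Compound 2 `O=C(O)C1=Cc2ccccc2OC1(OCc1cc(-c2ccc(F)cc2)no1)C(F)(F)F` likewise sits at the assay limit, > 150000 nM. Within the data shown here, the one measured step, an at least 3.0-fold lower number from compound 1 to compound 3 (0.48 log units; beyond the scatter), shows that the group on the shared core matters. Among the measured compounds shown here, compound 4 `CCOC(=O)C1=Cc2ccccc2OC1(OCc1cc(-c2ccc(F)cc2)no1)C(F)(F)F` differs from compound 3 by 4-fluorophenyl in place of 3-(trifluoromethyl)phenyl on an aromatic carbon, a move toward a smaller group resembling the one in compound 1, which sat at the limit of > 150000 nM in this assay, at which 2 of the 3 values shown sit. The step from compound 3 to compound 4 is therefore expected to raise the number, a 2.5-fold higher number from compound 3 to compound 4 (0.39 log units; beyond the scatter), with a real chance that only a limit is reported. Compound 4 is estimated at 120000 nM, within 40000 nM to 300000 nM.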

Compound 4, half-maximal inhibitory concentration: 35500 nM
Beside the measured number, compound 4's estimate is 3.4-fold (0.53 log units) above it; measured number outside the range, below it.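

In this assay, 4-fluorophenyl serves as well as 3-(trifluoromethyl)phenyl at this position, so compound 3 and compound 4 cannot be told apart: a 1.4-fold lower number from compound 3 to compound 4 (0.14 log units; within the scatter). Fluoro in place of methyl gives an at least 4.2-fold lower number from compound 1 to compound 4 (0.62 log units; beyond the scatter), and ethyl in place of hydrogen on the oxygen gives an at least 4.2-fold lower number from compound 2 to compound 4 (0.62 log units; beyond the scatter), so a small change on the phenyl ring or at the ester can matter more than the swap of the whole ring. Both of these steps start from a limit, not an exact number: the limit of > 150000 nM in this assay, at which 2 of the 4 values shown sit.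

As far as these compounds go, what an amine or a nitrile on that phenyl ring would do remains open, as does the effect of a chain longer than ethyl on that oxygen.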